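Tail-group swaps on the shared core: compound 3 to compound 4

The source may hold more compounds than are shown below. What is called first, only, known or untested is meant among the compounds shown, and "the series" means these compounds.

Measured so far in an assay on HeLa cells with Bile acid receptor (Homo sapiens) as the target, read by a luciferase reporter, with a stated time of 24 h; a higher number here means that more compound is needed for the effect, a lower number that less compound is needed:
compound 1 `C[S+]([O-])c1ccc(CNC(=O)c2ccc(C(C)(C)C)cc2)cc1` gives 1300 nM
compound 2 `CC(=O)c1ccc(CNC(=O)c2ccc(C(C)(C)C)cc2)cc1` gives 100 nM
compound 3 `CC(C)(C)c1ccc(C(=O)NCc2ccc(C(N)=O)cc2)cc1` gives 3800 nM

Both measured steps into compound 3, a 2.9-fold higher number from compound 1 to compound 3 (0.47 log units; beyond the scatter) and a 38-fold higher number from compound 2 to compound 3 (1.58 log units; beyond the scatter), go up, so it stands highest of the three. Compound 4 `COc1ccc(CNC(=O)c2ccc(C(C)(C)C)cc2)cc1` differs from it by methoxy in place of carbamoyl on an aromatic carbon.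

All three measured steps bear on this, since each exchanges the group on the same aromatic carbon: a 13-fold lower number from compound 1 to compound 2 (1.11 log units; beyond the scatter) is large, the other two are given above. The group at this place moves the number strongly, and carbamoyl gives the highest number of the three. Methoxy, like acetyl, brings 0 hydrogen-bond donors, so a lower number is expected for compound 4, by about a 7.6-fold lower number from compound 3 to compound 4 (0.88 log units; beyond the scatter), though not as far as compound 2 reached. Compound 4 is estimated at 500 nM, within 120 nM to 2000 nM.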

Compound 4, half-maximal effective concentration: 150 nM
Compound 4: middle estimate off by 3.3-fold (0.52 log units), on the high side; the measured number falls inside the stated range.
By their numbers in this assay, from the lowest: compounds 2 and 4 (each within the scatter of the next); then compound 1; then compound 3.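

In this assay methoxy on this aromatic carbon gives a 25-fold lower number from compound 3 to compound 4 (1.40 log units; beyond the scatter) and an 8.7-fold lower number from compound 1 to compound 4 (0.94 log units; beyond the scatter) while a 1.5-fold higher number from compound 2 to compound 4 (0.18 log units; within the scatter) leaves methoxy and acetyl within the scatter of each other. Acetyl is therefore not the only group giving a low number here, and a carbonyl on this carbon is not needed for one among the compounds shown. No measurement at hand accounts for these differences.

On these data alone, whether an amine, a carboxylic acid or a longer alkoxy chain on this carbon stays with methoxy and acetyl or moves toward carbamoyl remains open. As far as these compounds go, how the number responds to changes elsewhere on the shared core also remains open.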